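A few compounds are considered here, and "the series" means these few. Any claim that something is new, unique, unknown or untested is made for them only; others in the source may bear on it.

Two compounds of this series have numbers. Compound 1 `N=C(N)c1ccc(-c2ccc(-c3cncc4ccccc34)s2)s1` gives 1660 nM in a functional assay on NCI-H322M cells (Homo sapiens) for inhibition, read by sulforhodamine B assay, with a stated time of 48 h; a lower number here means a stronger inhibitor of growth, a higher number a weaker inhibitor of growth. Compound 2 `N=C(N)c1ccc(-c2ccc(-c3ccc(F)cc3)o2)o1` gives 1600 nM in this assay; its number sits alongside that of compound 1, the two within the usual scatter, so neither stands apart. Compound 3 `N=C(N)c1ccc(-c2ccc(-c3ccc(Cl)cc3)o2)o1` differs from compound 2 by chloro in place of fluoro on an aromatic carbon. Among the compounds with values here, no step between measured compounds is known for this exchange, so the expected step from compound 2 to compound 3 is small, if anything a slight lowering, within the scatter: a 1.2-fold lower number from compound 2 to compound 3 (0.09 log units; within the scatter). Compound 3 is expected to give about 1300 nM, the range estimated from 500 nM to 3500 nM.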

Compound 3, concentration for 50% growth inhibition: 1670 nM
Beside the measured number, compound 3's estimate is 1.3-fold (0.11 log units) below it; measured number inside the range.
By their numbers in this assay, from the lowest: compounds 2, 1 and 3 (each within the scatter of the next).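

In this assay chloro in place of fluoro on an aromatic carbon, para to a large group, gives a 1.0-fold higher number from compound 2 to compound 3 (0.02 log units; within the scatter) and so stays within the scatter. Within the data shown here, this position therefore accepts either halogen with no readable difference in growth inhibition, which the earlier compounds could not show. Nothing at hand offers an explanation for this result.

Going by these compounds, whether this position responds to any change at all remains open. An amine, a carboxylic acid or a methoxy group in place of the halogen would test that.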